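The source may report more compounds than this note shows. Statements on the series, on what has been measured and on what is new or still open speak of the compounds shown alone.

Of the compounds shown here, three built on one shared core have been measured in a functional assay on MCF7 cells (Homo sapiens) for inhibition, read by MTT assay, with a stated time of 48 h; on this read-out higher numbers stand for weaker inhibition and lower numbers for stronger inhibition. Compound 1 `COc1cccc(C(c2c[nH]c3ccc(Br)cc23)c2c[nH]c3ccc(Br)cc23)c1OC` gives 89000 nM in this assay, the highest of the three numbers and therefore the weakest inhibition seen so far. Compound 2 `COc1ccc(OC)c(C(c2c[nH]c3ccc(Br)cc23)c2c[nH]c3ccc(Br)cc23)c1` gives 2800 nM in this assay, and compound 3 `Clc1ccc(C(c2c[nH]c3ccc(Br)cc23)c2c[nH]c3ccc(Br)cc23)cc1` gives 3500 nM in this assay. The step of a 32-fold lower number from compound 1 to compound 2 (1.50 log units; beyond the scatter) and the step of a 25-fold lower number from compound 1 to compound 3 (1.41 log units; beyond the scatter) are both large and beyond the scatter, whereas the step of a 1.3-fold higher number from compound 2 to compound 3 (0.10 log units; within the scatter) lies within it.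

Compound 4 `CCCCCCCC(c1c[nH]c2ccc(Br)cc12)c1c[nH]c2ccc(Br)cc12` has not yet been measured. It differs from compound 1 in one place: heptyl in place of 2,3-dimethoxyphenyl on a saturated chain carbon bound to two aromatic carbons. The two measured steps from compound 1 bear on this change only loosely: each of them exchanges the 2,3-dimethoxyphenyl for another six-membered aromatic ring, while here a heptyl chain with no ring enters. What they do show is that leaving the 2,3-dimethoxyphenyl of compound 1 has twice lowered the number strongly. Among the compounds with values here, no step known so far tells how a chain behaves in this place, so the expected step of a 7.4-fold lower number from compound 1 to compound 4 (0.87 log units; beyond the scatter) is estimated to point downward but less far than the two earlier steps. For compound 4 the expected value in this assay is 12000 nM, with a range from 2500 nM to 60000 nM.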

Compound 4, half-maximal inhibitory concentration: 5500 nM
For compound 4 the middle estimate is 2.2-fold (0.34 log units) above the measured one; low and high end bracket the measured number.
By their numbers in this assay, from the lowest: compounds 2, 3 and 4 (each within the scatter of the next); then compound 1.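

In this assay the change to heptyl on a saturated chain carbon bound to two aromatic carbons gives a 16-fold lower number from compound 1 to compound 4 (1.21 log units; beyond the scatter) and so shows that a large drop from compound 1 does not require a new ring in this place. The chain also matches both ring-bearing compounds, with a 1.6-fold higher number from compound 3 to compound 4 (0.20 log units; within the scatter) and a 2.0-fold higher number from compound 2 to compound 4 (0.29 log units; within the scatter) both leaving compound 4 indistinguishable from them, so 4-chlorophenyl, 2,5-dimethoxyphenyl and heptyl cannot be ranked here, and compound 1 with its 2,3-dimethoxyphenyl stands alone as the weakest of the four. No measurement at hand explains why this one group stands apart from the other three.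

From the compounds shown here alone, how a shorter chain such as propyl, a longer chain such as dodecyl, or a heptyl chain ending in an amine or a carboxylic acid would behave in this place remains open. Also open, going by these compounds, is whether an unsubstituted phenyl would give a number like that of compound 1 or like those of the other three compounds.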